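From methyl to hydrogen in the alkyl series

The source may report more compounds than this note shows. Statements on the series, on what has been measured and on what is new or still open speak of the compounds shown alone.

In a functional assay on NCI-H460 cells (Homo sapiens) for cytotoxicity, read by MTT assay, with a stated time of 72 h (a lower number here means a stronger inhibitor, a higher number a weaker inhibitor), compound 1 `CC(C)(C)c1[nH]cnc1/C=c1\[nH]c(=O)/c(=C/c2cccc(C(=O)c3ccc(F)cc3)c2)[nH]c1=O` gives 3.8 nM and compound 2 `CC(C)c1[nH]cnc1/C=c1\[nH]c(=O)/c(=C/c2cccc(C(=O)c3ccc(F)cc3)c2)[nH]c1=O` gives 3.2 nM. The tert-butyl and isopropyl groups are not separated here: a 1.2-fold lower number from compound 1 to compound 2 (0.07 log units; within the scatter). Compound 3 `Cc1[nH]cnc1/C=c1\[nH]c(=O)/c(=C/c2cccc(C(=O)c3ccc(F)cc3)c2)[nH]c1=O`, the methyl member, has the highest number of the three at 15.9 nM. Two modest steps lead to it: a 4.2-fold higher number from compound 1 to compound 3 (0.62 log units; beyond the scatter) and a 5.0-fold higher number from compound 2 to compound 3 (0.70 log units; beyond the scatter). For the measured compounds named here, both put methyl in place of a larger group on an aromatic carbon, and they are the only guide to the next change.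

Compound 4 `O=C(c1ccc(F)cc1)c1cccc(/C=c2\[nH]c(=O)/c(=C/c3c[nH]cn3)[nH]c2=O)c1` differs from compound 3 by hydrogen in place of methyl on an aromatic carbon. Going by the values given here, no measured compound carries hydrogen at this place, so the expectation is an extrapolation. Starting from compound 3 at 15.9 nM, a further move to a higher number, beyond the scatter and of similar size, is expected in this assay, going by a 5.0-fold higher number from compound 2 to compound 3 (0.70 log units; beyond the scatter). The estimated step is a 2.8-fold higher number from compound 3 to compound 4 (0.45 log units; beyond the scatter). Compound 4 is expected at 45 nM, with an estimated range of 16 nM to 130 nM.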

Compound 4, half-maximal inhibitory concentration: 278 nM
Estimate against measurement, compound 4: 6.2-fold (0.79 log units) below; measured number outside the range, above it.
By their numbers in this assay, from the lowest: compounds 2 and 1 (each within the scatter of the next); then compound 3; then compound 4.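

At this place on the five-membered aromatic ring, the change from 5-methyl-1H-imidazol-4-yl to 1H-imidazol-4-yl is a large step in this assay (a 17-fold higher number from compound 3 to compound 4 (1.24 log units; beyond the scatter)), whereas the changes among the alkyl groups were modest or within the scatter. Against the two larger groups the distance is greater still (an 87-fold higher number from compound 2 to compound 4 (1.94 log units; beyond the scatter); a 73-fold higher number from compound 1 to compound 4 (1.86 log units; beyond the scatter)), so within these four compounds, all three alkyl-bearing compounds have lower numbers than compound 4, which carries only hydrogen here. Nothing measured on these compounds gives a reason for the size of this step.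

The compounds shown leave open whether any substituent at this place would hold the number down or only an alkyl group would. Chlorine, a methoxy group or an amine here would address that, while ethyl would fill the gap between methyl and isopropyl.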